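The source may report more compounds than this note shows. Statements on the series, on what has been measured and on what is new or still open speak of the compounds shown alone.

Measured in a functional assay on MV4-11 cells (Homo sapiens) for antiproliferative activity, read by CCK-8 assay, with a stated time of 72 h; a higher number here means a weaker inhibitor, a lower number a stronger inhibitor:
- compound 1, `Cn1cc(-c2cc(C(C)(C)O)ccc2OC2CC2)c2cc(C(=O)NCc3ccc(C(=O)NO)cc3)[nH]c2c1=O`, gives 420 nM
- compound 2, `Cn1cc(-c2cc(C(C)(C)O)ccc2Oc2ccc(F)cc2F)c2cc(C(=O)NCc3ccc(C(=O)NO)cc3)[nH]c2c1=O`, gives 190 nM
- compound 3, `Cn1cc(-c2cc(C(C)(C)O)ccc2Oc2ccc(F)cc2F)c2cc(C(=O)NCc3ccc(C(=O)Nc4ccccc4N)cc3)[nH]c2c1=O`, gives 90 nM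

Compound 4, `Cn1cc(-c2cc(C(C)(C)O)ccc2OC2CC2)c2cc(C(=O)NCc3ccc(C(=O)Nc4ccccc4N)cc3)[nH]c2c1=O`, has not yet been measured in this assay. It differs from compound 3 by cyclopropyl in place of 2,4-difluorophenyl on an oxygen on an aromatic ring. The same change has already been made once, from compound 2 to compound 1, where it reads cyclopropyl in place of 2,4-difluorophenyl on an oxygen on an aromatic ring and gave a 2.2-fold higher number from compound 2 to compound 1 (0.34 log units; beyond the scatter). The two cores on which this change sits differ from each other by 2-aminophenyl in place of hydroxy on an amide-type nitrogen; the place of the change is the same in both pairs. Among the measured compounds shown here, with only this single earlier step to go on, a step of similar size is expected from compound 3 to compound 4, a 2.2-fold higher number from compound 3 to compound 4 (0.35 log units; beyond the scatter), because of a 2.2-fold higher number from compound 2 to compound 1 (0.34 log units; beyond the scatter). Compound 4 is therefore estimated at 200 nM in this assay, most likely between 100 nM and 400 nM.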

Compound 4, half-maximal inhibitory concentration: 40 nM
Compound 4: the middle estimate sits 5.0-fold (0.70 log units) above what was measured; the whole stated range lies above it.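

In this assay, putting cyclopropyl in place of 2,4-difluorophenyl on the oxygen does not carry over from one core to the other; the new step, a 2.3-fold lower number from compound 3 to compound 4 (0.35 log units; beyond the scatter), runs opposite to the earlier one: the same change on two cores in this assay, a 2.2-fold higher number (0.34 log units; beyond the scatter) from compound 2 to compound 1 and a 2.3-fold lower number (0.35 log units; beyond the scatter) from compound 3 to compound 4, 5.0-fold (0.70 log units) apart, beyond the scatter of two such steps. Seen from the other side, 2-aminophenyl in place of hydroxy on the amide-type nitrogen gives a much larger step with cyclopropyl present, an 11-fold lower number from compound 1 to compound 4 (1.02 log units; beyond the scatter), than with 2,4-difluorophenyl present: the same change on two cores in this assay, a 2.1-fold lower number (0.32 log units; beyond the scatter) from compound 2 to compound 3 and an 11-fold lower number (1.02 log units; beyond the scatter) from compound 1 to compound 4, 5.0-fold (0.70 log units) apart, beyond the scatter of two such steps. So the effects of these two changes do not simply add up across these four compounds, but the data do not show why, or how far this holds beyond them.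

On these data alone, it remains open whether a methyl or an unsubstituted phenyl on that oxygen would follow cyclopropyl or 2,4-difluorophenyl on each core.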